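Changing the ether chain of compound 2

A few compounds are considered here, and "the series" means these few. Any claim that something is new, unique, unknown or untested is made for them only; others in the source may bear on it.

In a functional assay on MT2 cells (Homo sapiens) for cytotoxicity, read by MTT assay (on this read-out lower numbers stand for higher toxicity in this test and higher numbers for lower toxicity in this test), compound 1 `CCc1ccc(Nc2nccs2)cc1OCC=C(C)C` gives 31000 nM, while compound 2 `CC(C)=CCOc1cc(Nc2nccs2)ccc1C#N` gives 750 nM, the lower of the two numbers. Compound 3 `N#Cc1ccc(Nc2nccs2)cc1OCc1ccsc1` has thiophen-3-yl in place of 2-methylprop-1-en-1-yl on a saturated chain carbon bound to an oxygen on an aromatic ring. Among the compounds with values here, the sole measured step, a 41-fold lower number from compound 1 to compound 2 (1.62 log units; beyond the scatter), exchanged ethyl for cyano on an aromatic carbon, so no measured step tests this change directly. A modest rise is therefore expected, with wide uncertainty, and the expected step is a 2.4-fold higher number from compound 2 to compound 3 (0.38 log units; beyond the scatter). For compound 3, the estimated value is 1800 nM, with an expected range of 350 nM to 9000 nM.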

Compound 3, half-maximal cytotoxic concentration: 1100 nM
The estimate for compound 3 lay 1.6-fold (0.21 log units) above the measured number; the measured number falls inside the stated range.
By their numbers in this assay, from the lowest: compounds 2 and 3 (each within the scatter of the next); then compound 1.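

In this assay, the ether chain accepted an aromatic ring in place of an open chain, with a 1.5-fold higher number from compound 2 to compound 3 (0.17 log units; within the scatter) as the step. The read-out therefore does not separate 3-methylbut-2-en-1-yl from (thiophen-3-yl)methyl at this position, whereas the earlier step showed a large shift at a different place on the molecule. No available evidence explains why these two chains read alike.

Going by these compounds, whether an amine, a carboxylic acid or a longer chain on this oxygen would also read alike remains open. So does whether a phenyl ring would match thiophen-3-yl.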